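Replacing 1-acetylpiperidin-4-yl on a shared core

A few compounds are considered here, and "the series" means these few. Any claim that something is new, unique, unknown or untested is made for them only; others in the source may bear on it.

Compound 1 `Cn1nccc1-c1cnc(NCc2c(F)ccc3c2CCO3)c2cn[nH]c(=O)c12`: 2.6
Compound 2 `CC(=O)N1CCC(c2cnc(NCc3c(F)ccc4c3CCO4)c3cn[nH]c(=O)c23)CC1`: 2.9

Both values come from a physicochemical assay for lipophilicity, using the shake flask method, in phosphate buffer, measured as octanol-water partition, with a stated time of 30 min, at pH 7.4; a lower number here means a more polar compound, a higher number a more lipophilic compound. Compound 2, at 2.9, lies within the usual scatter of compound 1, so the two cannot be ranked. Compound 3 `CN(C)C(=O)c1cc(-c2cnc(NCc3c(F)ccc4c3CCO4)c3cn[nH]c(=O)c23)n(C)n1` has not yet been measured. It keeps the shared core but carries 3-(dimethylcarbamoyl)-1-methyl-1H-pyrazol-5-yl in place of 1-acetylpiperidin-4-yl on an aromatic carbon. Among the measured compounds shown here, only one measured step bears on this change: a number 0.30 log units higher from compound 1 to compound 2 (within the scatter). That step put the same 1-acetylpiperidin-4-yl in place of 1-methyl-1H-pyrazol-5-yl. Compound 3 returns to a pyrazole, but no measurement isolates the added dimethylcarbamoyl, so the forecast is uncertain. In this assay a modest downward step is expected, a number 0.40 log units lower from compound 2 to compound 3 (beyond the scatter). For compound 3 the estimated value is 2.5, with an expected range from 2.1 to 2.9.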

Compound 3, distribution coefficient: 2.1
The estimate for compound 3 lay 0.40 log units above the measured number, within the range that was stated.
By their numbers in this assay, from the lowest: compound 3; then compounds 1 and 2 (each within the scatter of the next).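

In this assay, the choice of group on this aromatic carbon had not yet given a difference that could be read, but now it does (a number 0.80 log units lower from compound 2 to compound 3 (beyond the scatter)). The closest comparison changes only one thing, dimethylcarbamoyl in place of hydrogen on the 1-methyl-1H-pyrazol-5-yl group, and this single change also gives a readable difference (a number 0.50 log units lower from compound 1 to compound 3 (beyond the scatter)). No measurement shown here offers an explanation for these differences.

On these data alone, whether a primary amide or a methyl ester in place of dimethylcarbamoyl would give a similar number remains open. It is also unknown whether dimethylcarbamoyl would produce a step of similar size on a ring other than the pyrazole.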